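Amide substituent swap in the dihydrofuran carboxamide series

The source may report more compounds than this note shows. Statements on the series, on what has been measured and on what is new or still open speak of the compounds shown alone.

Compound 1 `C=CC1=C(C(=O)NCc2ccc(Cl)cc2)C(c2ccc(F)cc2)OC1` is tested in a functional assay on A549 cells (Homo sapiens) for cytotoxicity, read by MTT assay, with a stated time of 24 h; a higher number here means a weaker inhibitor, a lower number a stronger inhibitor. In this assay compound 1 gives > 100000 nM, which is a limit of the assay and not a number. Compound 2 `C=CC1=C(C(=O)NCc2ccc(Cl)cc2)C(c2ccc(OC)cc2)OC1` is a close analogue carrying methoxy in place of fluoro on an aromatic carbon; in this assay compound 2 gives > 100000 nM, again a limit. The step between them, a step that the two limits leave unreadable from compound 1 to compound 2, cannot be read from the two limits. Both values sit at the same point, (the limit of > 100000 nM in this assay, at which 2 of the 2 values shown sit), so compound 1 stands at the limit with no finer placing.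

Compound 3 `C=CC1=C(C(=O)NC2CCCCC2)C(c2ccc(F)cc2)OC1` differs from compound 1 by cyclohexyl in place of 4-chlorobenzyl on an amide-type nitrogen. Among the compounds with values here, no measured step touches the amide-type nitrogen, so nothing speaks for or against this change. With compound 1 at a limit, compound 3 is expected to remain near it, an expected step that the limit leaves unreadable from compound 1 to compound 3. Compound 3 is estimated at 150000 nM, within the range 50000 nM to 500000 nM.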

Compound 3, half-maximal inhibitory concentration: > 100000 nM
Compound 3: only a limit was reported (the forecaster's own chance of this, stated with the estimate: 80%); the middle value does not contradict the limit.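

In this assay compound 3 gives > 100000 nM, a limit of the assay and not a number. Within the data shown here, compound 1 also stands at a limit, so no step to compound 3 can be read. Still open is how compound 1, compound 2 and compound 3 would rank under a readable value: the limit of > 100000 nM in this assay, at which 3 of the 3 values shown sit.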